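The compounds below may be only part of what the source reports. "The series", "measured", "known", "first", "only" and "open" are said of these compounds alone.

The series shares the core of compound 1 `COC(=O)c1c(F)cccc1-c1ccc(CCc2ncc(CC(C)(C)C)n2CCC(=O)O)cc1`, which in an assay on cells for agonist activity at Bombesin receptor subtype-3 (Homo sapiens), read by HTRF and inositol phosphate accumulation, with a stated time of 1 h (a higher number here means that more compound is needed for the effect, a lower number that less compound is needed), gives 1 nM. Compound 2 `COC(=O)c1c(F)cccc1-c1ccc(CCc2ncc(CC(C)(C)C)n2Cc2ccc(C(=O)O)cc2)cc1` gives 3 nM in this assay, and compound 3 `CC(C)(C)Cc1cnc(CCc2ccc(-c3cccc(F)c3C(=O)O)cc2)n1CCC(=O)O` gives 11 nM. Compound 3 thus stands highest of the three numbers measured; its nearest neighbour is compound 2 and its furthest is compound 1, both gaps beyond the scatter. Two measured steps frame the series: a 3.0-fold higher number from compound 1 to compound 2 (0.48 log units; beyond the scatter), and an 11-fold higher number from compound 1 to compound 3 (1.04 log units; beyond the scatter), the latter being hydrogen in place of methyl on an oxygen next to a carbonyl group. Compound 4 `CC(C)(C)Cc1cnc(CCc2ccc(-c3cccc(F)c3C(=O)O)cc2)n1Cc1ccc(C(=O)O)cc1` has not yet been measured; it differs from compound 3 by 4-carboxyphenyl in place of carboxymethyl on a saturated chain carbon bound to an aromatic nitrogen. The same change, made on compound 1 to give compound 2, bears directly on it and produced a modest rise, beyond the scatter. The change on compound 3 is therefore expected to give a step of similar size in the same direction: a 3.0-fold higher number from compound 3 to compound 4 (0.48 log units; beyond the scatter). Compound 4 is estimated at 33 nM, with a range from 12 nM to 90 nM.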

Compound 4, half-maximal effective concentration: 12 nM
Compound 4: the middle estimate sits 2.8-fold (0.44 log units) above what was measured, within the range that was stated.
By their numbers in this assay, from the lowest: compound 1; then compound 2; then compounds 3 and 4 (each within the scatter of the next).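

At this position, the change from 2-carboxyethyl to 4-carboxybenzyl does not add a fixed increment. It gives a 1.1-fold higher number from compound 3 to compound 4 (0.04 log units; within the scatter), so the size of the step depends on the core that carries it: the same change on two cores in this assay, a 3.0-fold higher number (0.48 log units; beyond the scatter) from compound 1 to compound 2 and a 1.1-fold higher number (0.04 log units; within the scatter) from compound 3 to compound 4, 2.8-fold (0.44 log units) apart, beyond the scatter of two such steps

Read the other way, hydrogen in place of methyl on the oxygen next to a carbonyl group still gives a step beyond the scatter with 4-carboxyphenyl in place, a 4.0-fold higher number from compound 2 to compound 4 (0.60 log units; beyond the scatter), but a smaller one than with carboxymethyl: the same change on two cores in this assay, an 11-fold higher number (1.04 log units; beyond the scatter) from compound 1 to compound 3 and a 4.0-fold higher number (0.60 log units; beyond the scatter) from compound 2 to compound 4, 2.8-fold (0.44 log units) apart, beyond the scatter of two such steps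

The compounds shown leave open whether the carboxylic acid of the 4-carboxyphenyl group matters at this position, since a primary amide or an unsubstituted benzyl group on the same saturated chain carbon is not among them. They also leave open how a longer chain ending in a carboxylic acid would behave on either core.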